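Swapping a ring on the amine nitrogen: compound 2 to compound 3

The source may hold more compounds than are shown below. What is called first, only, known or untested is meant among the compounds shown, and "the series" means these compounds.

Of the compounds shown here, two sharing a core have been measured in an assay on isolated protein (Bos taurus) with 5-hydroxytryptamine receptor 1D (Homo sapiens) as the target; on this read-out lower numbers stand for stronger inhibition and higher numbers for weaker inhibition. Compound 1 `c1cnc(NCCNCC2CCc3ccccc3O2)nc1` gives 31.6 nM. Compound 2 `c1ccc2c(c1)CCC(CNCCCNC1=NCCCC1)O2` gives 3.98 nM, the lowest of the two numbers and well separated from compound 1, a gap beyond the usual scatter. Compound 3 `Clc1ccc(NCCCNCC2CCc3ccccc3O2)nn1` is not yet measured; it differs from compound 2 in one place: a group of 7 heavy atoms (4 carbon, 2 nitrogen, 1 chlorine; one six-membered aromatic ring with 2 hetero atoms) in place of a group of 6 heavy atoms (5 carbon, 1 nitrogen; one six-membered non-aromatic ring with 1 hetero atom), on an amine nitrogen. Within the data shown here, no measured pair shows this exact exchange, so its effect is unknown. Compound 3 is expected to give a somewhat higher number than compound 2, estimated as a 5.0-fold higher number from compound 2 to compound 3 (0.70 log units; beyond the scatter), because compound 1 gives 31.6 nM. The estimate for compound 3 is 20 nM, within 6 nM to 70 nM.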

Compound 3, half-maximal inhibitory concentration: 2 nM
The estimate for compound 3 lay 10-fold (1.00 log units) above the measured number; measured number outside the range, below it.
By their numbers in this assay, from the lowest: compounds 3 and 2 (each within the scatter of the next); then compound 1.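

In this assay the exchange of the non-aromatic ring for 6-chloropyridazin-3-yl on the amine nitrogen gives a 2.0-fold lower number from compound 2 to compound 3 (0.30 log units; within the scatter) and so leaves the number essentially unchanged. Among these compounds, this is the first direct look at this position, and it accepts an aromatic ring carrying chlorine as readily as a non-aromatic ring. Nothing measured here explains this result.

The compounds shown leave open whether the chlorine matters to this result. They also leave open whether a plain phenyl ring or an unsubstituted pyridazine on the same nitrogen would read the same.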